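The source may hold more compounds than are shown below. What is called first, only, known or untested is meant among the compounds shown, and "the series" means these compounds.

Measured so far:
- compound 1 `COc1ccc(/C=C/C[C@H]2C[C@@H]([C@@H](O)c3ccccc3)CO[C@@H]2c2ccccc2)cc1`: 8300 nM
- compound 2 `COc1ccc(/C=C/C[C@@H]2C[C@@H]([C@@H](O)c3ccc(OC)c(OC)c3)CO[C@H]2c2ccccc2)cc1OC`: 16100 nM

In a functional assay on HeLa cells (Homo sapiens) for cytotoxicity, read by WST assay, with a stated time of 48 h (a lower number here means a stronger inhibitor, a higher number a weaker inhibitor), compound 1 gives 8300 nM and compound 2 gives 16100 nM; the two numbers lie within the scatter of each other, so neither is set apart. Among the compounds with values here, no step between measured compounds changes one place only, so there is no reference for the move to compound 3 `O[C@@H](c1ccccc1)[C@H]1CO[C@H](c2ccccc2)[C@@H](C/C=C/C2CCCCC2)C1`.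

Compound 3 differs from compound 1 by cyclohexyl in place of 4-methoxyphenyl on a double-bonded chain carbon bound to a double-bonded chain carbon. With nothing to calibrate it, only a modest step is expected in this assay, perhaps none beyond the scatter, leaning toward a higher number. For compound 3 the estimated step is a 1.4-fold higher number from compound 1 to compound 3 (0.16 log units; within the scatter). Compound 3 is expected at 12000 nM, within 4000 nM to 40000 nM.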

Compound 3, half-maximal inhibitory concentration: 6440 nM
For compound 3 the middle estimate is 1.9-fold (0.27 log units) above the measured one; low and high end bracket the measured number.
By their numbers in this assay, from the lowest: compounds 3, 1 and 2 (each within the scatter of the next, the first and the last beyond it).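

In this assay, cyclohexyl in place of 4-methoxyphenyl on a double-bonded chain carbon bound to a double-bonded chain carbon gives a 1.3-fold lower number from compound 1 to compound 3 (0.11 log units; within the scatter) and so leaves the read-out within the scatter. At this place, then, an aromatic ring can give way to a non-aromatic ring of carbon only without a step beyond the scatter, on the evidence of this single pair. No supporting data bear on the reason for this result.

Open, going by these compounds, is whether an amine, a carboxylic acid or a plain butyl chain at this place would behave the same way. Also open, on these data alone, is whether the same exchange gives a similar step on the core of compound 2.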